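Notes: cyano in place of nitro on aromatic carbon

The source may report more compounds than this note shows. Statements on the series, on what has been measured and on what is new or still open speak of the compounds shown alone.

Measured in a functional assay on B16-F10 cells (Mus musculus) for inhibition, read by MTT assay, with a stated time of 72 h; a lower number here means a stronger inhibitor, a higher number a weaker inhibitor:
- compound 1 `CC1(C)CC(NC(=S)Nc2cccc(C#N)c2)c2cc(F)ccc2O1`: 35000 nM
- compound 2 `CC1(C)CC(NC(=S)Nc2ccc(C#N)cc2)c2cc(Cl)ccc2O1`: 7000 nM
- compound 3 `CC1(C)CC(NC(=S)Nc2cccc([N+](=O)[O-])c2)c2cc(Cl)ccc2O1`: 6000 nM

Compound 3 lies within the scatter of compound 2, and compound 1 gives a higher number, beyond the scatter of compound 3. Compound 4 `CC1(C)CC(NC(=S)Nc2cccc(C#N)c2)c2cc(Cl)ccc2O1` carries cyano in place of nitro on an aromatic carbon, meta to a large group: cyano in place of nitro on an aromatic carbon. Among the compounds with values here, no measured pair isolates this change. Compound 2 also carries cyano and gives 7000 nM, so no step beyond the scatter is expected in this assay. The expected change is a 1.3-fold higher number from compound 3 to compound 4 (0.12 log units; within the scatter). For compound 4 the estimated value is 8000 nM, with an expected range of 3500 nM to 20000 nM.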

Compound 4, half-maximal inhibitory concentration: 6000 nM
Estimate against measurement, compound 4: 1.3-fold (0.12 log units) above, within the range that was stated.
By their numbers in this assay, from the lowest: compounds 3, 4 and 2 (each within the scatter of the next); then compound 1.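

In this assay, within the data shown here, cyano in place of nitro on an aromatic carbon, meta to a large group, gives no change at the digits printed from compound 3 to compound 4 (within the scatter) as the first matched reading of this change, and 3-cyanophenyl in place of 4-cyanophenyl on an amide-type nitrogen gives a 1.2-fold lower number from compound 2 to compound 4 (0.07 log units; within the scatter) and does not separate the two cyano placements. Chloro in place of fluoro on an aromatic carbon gives a 5.8-fold lower number from compound 1 to compound 4 (0.77 log units; beyond the scatter) and is the only step here beyond the scatter. No measured data explain these steps.

Going by these compounds, whether an amine or a carboxylic acid at this aromatic position would keep the number in this assay stays open. Also open, on these data alone, is how bromo in place of chloro would read.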